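A few compounds are considered here, and "the series" means these few. Any claim that something is new, unique, unknown or untested is made for them only; others in the source may bear on it.

Measured compounds in a functional assay on the whole organism with Rattus norvegicus as the target, in the maximal electroshock model; a lower number here means that less compound is needed, a higher number that more compound is needed for the effect:

Compound 1, `CCNc1ncnc2c1ncn2Cc1ccccc1F`, gives 4.9 mg/kg.
Compound 2, `CC(C)Nc1ncnc2c1ncn2Cc1ccccc1F`, gives 5.8 mg/kg.
Compound 3, `CCN(C)c1ncnc2c1ncn2Cc1ccccc1F`, gives 2.9 mg/kg.

All three share a core and differ only in the amine. From compound 1 to compound 3 the difference is methyl in place of hydrogen on a nitrogen on an aromatic ring, and this step reads a 1.7-fold lower number from compound 1 to compound 3 (0.23 log units; within the scatter). From compound 2 to compound 3 the change is a 2.0-fold lower number from compound 2 to compound 3 (0.30 log units; within the scatter). Both steps stay inside the usual scatter, so no order among the three can be claimed.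

Compound 4, `CCN(CC)c1ncnc2c1ncn2Cc1ccccc1F`, is not yet measured. It differs from compound 3 by methyl in place of hydrogen on a saturated chain carbon bound to a nitrogen on an aromatic ring. The same kind of change has already been made once, from compound 1 to compound 2, as methyl in place of hydrogen on a saturated chain carbon bound to a nitrogen on an aromatic ring and a saturated chain carbon; there the step was a 1.2-fold higher number from compound 1 to compound 2 (0.07 log units; within the scatter). The two places are not identical: in compound 1 the carbon carrying the new methyl is bound to a nitrogen on an aromatic ring and a saturated chain carbon, whereas in compound 3 it is bound only to a nitrogen on an aromatic ring, so the two changes are the same kind rather than the same.

For compound 4 in this assay the expected step is a 1.2-fold higher number from compound 3 to compound 4 (0.07 log units; within the scatter), resting on compound 1 to compound 2, which gave a 1.2-fold higher number from compound 1 to compound 2 (0.07 log units; within the scatter), a step within the scatter. Compound 4 is therefore estimated at 3.4 mg/kg, with a likely range from 1.7 mg/kg to 7 mg/kg.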

Compound 4, dose for half-maximal effect: 4.2 mg/kg
Estimate against measurement, compound 4: 1.2-fold (0.09 log units) below; measured number inside the range.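

In this assay, methyl in place of hydrogen on a saturated chain carbon bound to a nitrogen on an aromatic ring behaves alike on both cores: the same change on two cores in this assay, a 1.2-fold higher number (0.07 log units; within the scatter) from compound 1 to compound 2 and a 1.4-fold higher number (0.16 log units; within the scatter) from compound 3 to compound 4, 1.2-fold (0.09 log units) apart, within the scatter of two such steps

The other new steps, a 1.4-fold lower number from compound 2 to compound 4 (0.14 log units; within the scatter) and a 1.2-fold lower number from compound 1 to compound 4 (0.07 log units; within the scatter), are also within the scatter, as is a 1.4-fold higher number from compound 3 to compound 4 (0.16 log units; within the scatter), so the four amines cannot be ordered in this assay. Within the data shown here, this agreement shows only that the change has no readable effect on either core; with both steps this small and only two pairs, it does not show that a real effect of a given size carries from one core to another, and it gives no rule for the series.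

Going by these compounds, whether a longer chain on the nitrogen, such as propyl or butyl, would give a step beyond the scatter stays open. The same holds for a cyclic amine such as pyrrolidine or morpholine, or for the unsubstituted amino group.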